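A few compounds are considered here, and "the series" means these few. Any claim that something is new, unique, unknown or untested is made for them only; others in the source may bear on it.

Measured compounds: compound 1 `CNc1nc(Nc2ccc(C#N)cc2)nc(Oc2ccc3cc(Br)ccc3c2Br)n1` gives 92800 nM; compound 2 `N#Cc1ccc(Nc2nc(N)nc(Oc3ccc4cc(Br)ccc4c3Br)n2)cc1` gives 244000 nM; compound 3 `CNc1nc(Nc2ccc(C#N)cc2)nc(Oc2ccc3ccccc3c2Cl)n1` gives 171000 nM.

These three were tested in an ADME assay on MT4 cells (Homo sapiens) for cytotoxicity, read by MTT assay, with a stated time of 4 days; a higher number here means that more compound is tolerated, a lower number that less compound is tolerated. Compound 1 and compound 2 differ by one change, (hydrogen in place of methyl on a nitrogen on an aromatic ring), and that change produced a 2.6-fold higher number from compound 1 to compound 2 (0.42 log units; beyond the scatter). The difference between the core of compound 1 and the core of compound 3 is not broken down here. Compound 4 `N#Cc1ccc(Nc2nc(N)nc(Oc3ccc4ccccc4c3Cl)n2)cc1` is still unmeasured; it differs from compound 3 by hydrogen in place of methyl on a nitrogen on an aromatic ring, the same change seen between compound 1 and compound 2. Among the compounds with values here, from compound 3 to compound 4 the step in this assay is expected to be a 2.3-fold higher number from compound 3 to compound 4 (0.37 log units; beyond the scatter), an expectation that rests on the single earlier step of a 2.6-fold higher number from compound 1 to compound 2 (0.42 log units; beyond the scatter) from compound 1 to compound 2. On that basis compound 4 is estimated at 400000 nM, with a likely range from 180000 nM to 900000 nM.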

Compound 4, half-maximal cytotoxic concentration: 32200 nM
Estimate against measurement, compound 4: 12-fold (1.09 log units) above; the whole stated range lies above it.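

In this assay the change from methylamino to amino gave a 5.3-fold lower number from compound 3 to compound 4 (0.73 log units; beyond the scatter) and so did not carry over from one core to the other, in direction or in size: the same change on two cores in this assay, a 2.6-fold higher number (0.42 log units; beyond the scatter) from compound 1 to compound 2 and a 5.3-fold lower number (0.73 log units; beyond the scatter) from compound 3 to compound 4, 14-fold (1.14 log units) apart, beyond the scatter of two such steps. In these two pairs, then, the outcome of the change goes with the core that carries it, and a step read on one core did not predict the step on the other. This does not show which part of the cores decides the outcome, as the difference between them is not broken down, and two pairs set no rule for the wider series.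

From the compounds shown here alone, it remains open how an ethylamino or dimethylamino group in the same place would read in this assay on either core.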